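A few compounds are considered here, and "the series" means these few. Any claim that something is new, unique, unknown or untested is made for them only; others in the source may bear on it.

Measured so far in a functional assay on CHO cells for antagonist activity at Orexin receptor type 2 (Homo sapiens), read by FLIPR and calcium flux; on this read-out lower numbers stand for stronger inhibition and higher numbers for weaker inhibition:
- compound 1 `Cc1ccc(C)c(NC(=O)CSc2nnc(-c3ccoc3C)n2Cc2ccco2)c1`: 398 nM
- compound 2 `COc1ccc(NC(=O)CSc2nnc(-c3ccoc3C)n2Cc2ccco2)cc1`: 200 nM

Compound 2 holds the lower of the two numbers, but the step of a 2.0-fold lower number from compound 1 to compound 2 (0.30 log units; within the scatter) stays within the scatter, so the two aryl amides read as equivalent. Compound 3 `Cc1occc1-c1nnc(SCC(N)=O)n1Cc1ccco1` takes the change (hydrogen in place of 4-methoxyphenyl on an amide-type nitrogen). Going by the values given here, only the step from compound 1 to compound 2 touches this position, and it swaps one aryl group for another rather than removing one, so it offers little direct guidance. Removing the aryl altogether is expected to weaken inhibition markedly, as a 15-fold higher number from compound 2 to compound 3 (1.18 log units; beyond the scatter). Compound 3 is therefore estimated at 3000 nM, in the range 800 nM to 12000 nM.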

Compound 3, inhibition constant: > 15800 nM
Compound 3 gave a limit, no number (the forecaster's own chance of this, stated with the estimate: 25%); middle value at least 5.2-fold (0.72 log units) away from the limit.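

In this assay, compound 3 gives only a limit, not a number: the limit of > 15800 nM in this assay, at which 1 of the 3 values shown sits.

Hydrogen on the amide-type nitrogen costs far more than exchanging one aryl group for another: an at least 79-fold higher number from compound 2 to compound 3 (1.89 log units; beyond the scatter), and an at least 39-fold higher number from compound 1 to compound 3 (1.59 log units; beyond the scatter), whereas a 2.0-fold lower number from compound 1 to compound 2 (0.30 log units; within the scatter). Across compound 1, compound 2 and compound 3, inhibition therefore depends on an aryl group at this nitrogen, and the two aryl groups read alike.

The limit leaves the full size of the loss open. Also open, as far as these compounds go, is whether a smaller group on this nitrogen, such as methyl, or a benzyl group would retain inhibition.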